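The source may hold more compounds than are shown below. What is called first, only, known or untested is meant among the compounds shown, and "the series" means these compounds.

Compound 3, `Cc1ccc(OCCCCCn2ccc(=O)[nH]c2=O)cc1`, gives 100000 nM in an ADME assay on HEL cells (Homo sapiens) for cytotoxicity, read by microscopy (a lower number here means that less compound is tolerated, a higher number that more compound is tolerated), level with compound 1, `O=c1ccn(CCCCCOc2ccc(Br)cc2)c(=O)[nH]1`, which gives 100000 nM in this assay; the step of no change at the digits printed from compound 1 to compound 3 (within the scatter) lies within the scatter. Compound 2, `Nc1ccc(OCCCCCn2ccc(=O)[nH]c2=O)cc1`, reaches only a limit of this assay, > 100000 nM. The step of a number no lower from compound 1 to compound 2 (the limit leaves the size open) is thus open in size, as is a number no higher from compound 2 to compound 3 (the limit leaves the size open). Compound 4, `Cc1cccc(OCCCCCn2ccc(=O)[nH]c2=O)c1`, differs from compound 3 by 3-methylphenyl in place of 4-methylphenyl on an oxygen on a saturated carbon. Within the data shown here, none of the measured steps moves the methyl group itself; they exchange the group on the aromatic carbon and leave this assay flat or at the limit. Compound 4 is therefore expected to give 100000 nM in this assay, with a range from 50000 nM to 200000 nM, a step of no change at the digits printed from compound 3 to compound 4 (within the scatter) expected to lie within the scatter.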

Compound 4, minimum cytotoxic concentration: > 100000 nM
Compound 4 was reported as a limit; the forecaster's own chance of this, stated with the estimate: 40%; the middle value lies on the limit itself.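

With 3-methylphenyl in place of 4-methylphenyl on the oxygen, the result in this assay is a number no lower from compound 3 to compound 4 (the limit leaves the size open), and against the bromo compound it is a number no lower from compound 1 to compound 4 (the limit leaves the size open). As far as these compounds go, compound 4 gives > 100000 nM, which is a limit of the assay, so the size of both steps stays open and the step between compound 2 and compound 4 cannot be read at all. A change that keeps the same atoms, joined differently, thus ends at the same limit as the amino compound: the limit of > 100000 nM in this assay, at which 2 of the 4 values shown sit.

From the compounds shown here alone, how far compound 4 lies past this limit remains open. So does whether a methoxy group or a carboxylic acid on the aromatic carbon, or a longer chain, would also stay at it.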